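Aryl variation on the saturated ring carbon of the pyrazoline series

A few compounds are considered here, and "the series" means these few. Any claim that something is new, unique, unknown or untested is made for them only; others in the source may bear on it.

Measured so far:
- compound 1 `O=c1oc2ccccc2cc1C1=NN(c2ccccc2)[C@@H](c2ccc(Cl)cc2Cl)C1` gives 56.7%
- compound 2 `O=c1oc2ccccc2cc1C1=NN(c2ccccc2)[C@@H](c2cccc([N+](=O)[O-])c2)C1` gives 26.1%

Of the compounds shown here, two have been read in a functional assay on the whole organism (strain albino) for inhibition, with Rattus norvegicus as the target, read by paw edema, with stated times of 1 h and 2 h, at a dose of 200 mg/kg by the oral route; a higher number here means more inhibition at the dose given (going by the name of the read-out), a lower number less inhibition. Compound 2 stands at the lower of the two numbers; its nearest neighbour is compound 1, and the step of a number 30.6 percentage points lower from compound 1 to compound 2 (beyond the scatter) is the only one measured. Going by the values given here, that step is the sole guide to how the aryl group on the saturated ring carbon moves the read-out.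

The next compound, compound 3 `Cc1ccc([C@H]2CC(c3cc4ccccc4oc3=O)=NN2c2ccccc2)cc1`, has not yet been measured. Its difference from compound 2 is 4-methylphenyl in place of 3-nitrophenyl on a saturated ring carbon. Among the compounds with values here, no measured step covers a methylphenyl group here, so the one step between compound 1 and compound 2 bears on it only loosely: it shows that the aryl group on that carbon can shift the read-out by a large amount in this assay, without telling which way a 4-methylphenyl group will go.

Within the data shown here, the expectation is therefore a return towards the middle of the two known numbers, with the step of a number 13.9 percentage points higher from compound 2 to compound 3 (beyond the scatter) expected and compound 3 estimated at 40%, in a range from 24% to 56%.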

Compound 3, a percentage reported as inhibition, in the whole organism at one dose (the size of the read-out at that dose, not a potency): 30.1%
For compound 3 the middle estimate is 9.9 percentage points above the measured one; measured number inside the range.
By their numbers in this assay, from the lowest: compounds 2 and 3 (each within the scatter of the next); then compound 1.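

In this assay the exchange of 3-nitrophenyl for 4-methylphenyl on the saturated ring carbon gives a number 4 percentage points higher from compound 2 to compound 3 (within the scatter), so at this dose the two aryl groups cannot be told apart, although one carries a nitro group and the other a methyl group. The comparison with the 2,4-dichlorophenyl group now has a second partner, with a number 26.6 percentage points lower from compound 1 to compound 3 (beyond the scatter), which shows that the gap first seen with compound 2 is not particular to the 3-nitrophenyl group: compound 1 has the highest number of the three, and its steps to both others lie beyond the scatter. Nothing at hand explains why the aryl groups at this position rank as they do.

The compounds shown leave open whether a single chlorine, as in 4-chlorophenyl or 2-chlorophenyl, keeps the number of compound 1 or whether both chlorines together go with it. Also open, from the compounds shown here alone, is how an unsubstituted phenyl, a 4-methoxyphenyl or a 4-carboxyphenyl group on the same saturated ring carbon would read against these three.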